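Three Diaryl Ureas and an Untested Trimethyl Analogue

The source may report more compounds than this note shows. Statements on the series, on what has been measured and on what is new or still open speak of the compounds shown alone.

Compound 1 `COc1cc(C)nc(OC)c1NC(=O)N(Cc1ccc(Oc2ccc(F)cc2)cc1)C1CCCCCC1` gives 33 nM in an assay for inhibition of acyl-CoA:cholesterol acyltransferase (Oryctolagus cuniculus), using microsomes; a lower number here means a stronger inhibitor, a higher number a weaker inhibitor.
Compound 2 `CSc1cc(C)nc(Cl)c1NC(=O)N(Cc1ccc(Oc2ccc(F)cc2)cc1)C1CCCCCC1` gives 46 nM in this assay.
Compound 3 `Cc1cc(S(C)(=O)=O)c(NC(=O)N(Cc2ccc(Oc3ccc(F)cc3)cc2)C2CCCCCC2)c(Cl)n1` gives 30 nM in this assay.

All three compounds share the same core and differ only in the substituted ring attached to the amide-type nitrogen. Compound 3 sits at the low end of the three numbers, yet the gaps are small: a 1.1-fold lower number from compound 1 to compound 3 (0.04 log units; within the scatter) and a 1.5-fold lower number from compound 2 to compound 3 (0.19 log units; within the scatter) both fall within the scatter, as does a 1.4-fold higher number from compound 1 to compound 2 (0.14 log units; within the scatter). Across these swaps of ring substituents, the read-out barely moved.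

Compound 4 `Cc1cc(C)c(NC(=O)N(Cc2ccc(Oc3ccc(F)cc3)cc2)C2CCCCCC2)c(C)n1` carries the next such swap: a group of 9 heavy atoms (8 carbon, 1 nitrogen; one six-membered aromatic ring with 1 hetero atom) in place of a group of 12 heavy atoms (7 carbon, 1 nitrogen, 2 oxygen, 1 sulfur, 1 chlorine; one six-membered aromatic ring with 1 hetero atom), on an amide-type nitrogen. The two comparable exchanges on the same position, a 1.4-fold higher number from compound 1 to compound 2 (0.14 log units; within the scatter) and a 1.1-fold lower number from compound 1 to compound 3 (0.04 log units; within the scatter), each stayed within the scatter, so no step beyond the scatter is expected here either, in either direction. Compound 4 is therefore estimated at about 40 nM, with a range from 15 nM to 120 nM. That estimate corresponds to a 1.3-fold higher number from compound 3 to compound 4 (0.12 log units; within the scatter), a step expected to remain inside the usual scatter.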

Compound 4, half-maximal inhibitory concentration: 62 nM
Beside the measured number, compound 4's estimate is 1.6-fold (0.19 log units) below it; low and high end bracket the measured number.
By their numbers in this assay, from the lowest: compounds 3, 1, 2 and 4 (each within the scatter of the next, the first and the last beyond it).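

Within the data shown here, the 2,4,6-trimethylpyridin-3-yl group on the amide-type nitrogen gives the first step at this position to pass the scatter (a 2.1-fold higher number from compound 3 to compound 4 (0.32 log units; beyond the scatter)), so the ring carried here is not entirely without consequence in this assay. This is a modest step, and it is the only one of its kind: the same group stays within the scatter against the other two rings (a 1.3-fold higher number from compound 2 to compound 4 (0.13 log units; within the scatter); a 1.9-fold higher number from compound 1 to compound 4 (0.27 log units; within the scatter)), so it separates compound 4 from compound 3 alone. No measurement shown here offers an explanation for this difference.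

The swap to compound 4 changes several ring substituents at once, so the compounds shown cannot assign the step to any single one of them. A ring carrying an amine or a longer chain such as ethyl remains an open case at this position.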